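Arylidene series on the breast cancer cell line: notes toward compound 4

The source may report more compounds than this note shows. Statements on the series, on what has been measured and on what is new or still open speak of the compounds shown alone.

Measured so far in a functional assay on MDA-MB-231 cells (Homo sapiens) for cytotoxicity, read by MTT assay, with a stated time of 72 h; a lower number here means a stronger inhibitor, a higher number a weaker inhibitor:
- compound 1 `O=C1N/C(=N/c2csc(-c3ccc(Cl)cc3)c2)S/C1=C\c1ccccc1`: 18000 nM
- compound 2 `COc1ccc(/C=C2\S/C(=N\c3csc(-c4ccc(Cl)cc4)c3)NC2=O)cc1`: 1200 nM
- compound 3 `O=C1N/C(=N/c2csc(-c3ccc(Cl)cc3)c2)S/C1=C\c1ccc(O)cc1`: "not determined" (no result reported)

Compound 3 therefore has no number to stand on; it is known only as a structure, and its place relative to compound 1 and compound 2 in this assay cannot be read from the data.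

Compound 4 `O=C1N/C(=N/c2csc(-c3ccc(Cl)cc3)c2)S/C1=C\c1ccccn1` carries pyridin-2-yl in place of 4-hydroxyphenyl on a double-bonded chain carbon bound to a double-bonded ring carbon on the shared core. For the measured compounds named here, the only step measured is a 15-fold lower number from compound 1 to compound 2 (1.18 log units; beyond the scatter), which shows that a change on the pendant aromatic ring can move this assay strongly. Going by the values given here, no measured pair involves a ring nitrogen, so the direction for compound 4 is open. For compound 4 the value in this assay is expected near 6000 nM, with a range from 1500 nM to 25000 nM.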

Compound 4, half-maximal inhibitory concentration: 10900 nM
The estimate for compound 4 lay 1.8-fold (0.26 log units) below the measured number; the range from low to high includes it.
By their numbers in this assay, from the lowest: compound 2; then compounds 4 and 1 (each within the scatter of the next).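

In this assay, pyridin-2-yl in place of phenyl on this double-bonded chain carbon brings no resolved change (a 1.7-fold lower number from compound 1 to compound 4 (0.22 log units; within the scatter)), so a ring nitrogen here does not separate compound 4 from compound 1. Against 4-methoxyphenyl the same group falls well behind (a 9.1-fold higher number from compound 2 to compound 4 (0.96 log units; beyond the scatter)), leaving compound 2 alone at the low end of the measured set. Nothing measured on these compounds accounts for this difference.

Steps involving compound 3 cannot be read, so the place of 4-hydroxyphenyl stays unknown. As far as these compounds go, whether an amine or a carboxylic acid on the pendant ring would match 4-methoxyphenyl remains open.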